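A few compounds are considered here, and "the series" means these few. Any claim that something is new, unique, unknown or untested is made for them only; others in the source may bear on it.

Measured so far in an ADME assay on J774 cells (Mus musculus) for cytotoxicity, read by MTT assay, with a stated time of 48 h; on this read-out lower numbers stand for stronger inhibition and higher numbers for weaker inhibition:

Compound 1 `CCOC(=O)c1c(C(F)(F)F)[n+]([O-])c2ccc(C(F)(F)F)cc2[n+]1[O-]` gives 4200 nM.
Compound 2 `COC(=O)c1c(C(F)(F)F)[n+]([O-])c2ccc(C(F)(F)F)cc2[n+]1[O-]` gives 4000 nM.
Compound 3 `COC(=O)c1c(C(F)(F)F)[n+]([O-])c2cc(Cl)c(Cl)cc2[n+]1[O-]` gives 500 nM.

Compound 1 stands highest of the three numbers; compound 2 lies within the scatter of it, as the step of a 1.1-fold lower number from compound 1 to compound 2 (0.02 log units; within the scatter) shows, while compound 3 sits well lower. Compound 4 `CCOC(=O)c1c(C(F)(F)F)[n+]([O-])c2ccccc2[n+]1[O-]` differs from compound 1 by hydrogen in place of trifluoromethyl on an aromatic carbon, the group leaving from a position meta to a fused ring and para to a fused ring. Among the compounds with values here, no measured step touches this position: the one step known alters only the ester, and compound 3 differs from compound 2 in two places at once, so its values show only that the ring substitution can matter. A step of no clear size beyond the scatter is therefore expected for a 1.2-fold higher number from compound 1 to compound 4 (0.08 log units; within the scatter), with wide uncertainty. Compound 4 is estimated at 5000 nM, range 1500 nM to 15000 nM.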

Compound 4, half-maximal inhibitory concentration: 4000 nM
Beside the measured number, compound 4's estimate is 1.3-fold (0.10 log units) above it, within the range that was stated.
By their numbers in this assay, from the lowest: compound 3; then compounds 2, 4 and 1 (each within the scatter of the next).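

In this assay, the change at this aromatic carbon, taken alone, gives no readable shift (a 1.1-fold lower number from compound 1 to compound 4 (0.02 log units; within the scatter)). With the ethyl ester core of compound 1, trifluoromethyl at this place can therefore give way to hydrogen without a change beyond the scatter. No measurement at hand offers an explanation for this result.

From the compounds shown here alone, whether an amine or a methoxy group on this carbon would also stay within the scatter remains open. Also open, going by these compounds, is whether a single chlorine here, apart from any second ring change, would move the number.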